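The source may report more compounds than this note shows. Statements on the series, on what has been measured and on what is new or still open speak of the compounds shown alone.

Values in a physicochemical assay for lipophilicity, at pH 7.4 (on this read-out lower numbers stand for lower lipophilicity and higher numbers for higher lipophilicity), so far:
- compound 1 `CC(C)CN(c1ccc(C#N)cc1)S(=O)(=O)c1ccc2c(c1)C(=O)CC(C1CCOCC1)O2` gives 3.16
- compound 2 `CC(C)CN(c1cccc(F)c1)S(=O)(=O)c1ccc2c(c1)C(=O)CC(C1CCOCC1)O2` gives 3.5
- compound 3 `Cc1ccc(N(CC(C)C)S(=O)(=O)c2ccc3c(c2)C(=O)CC(C2CCOCC2)O3)c(C)c1` gives 4.28

Compound 3 stands highest of the three, and its steps to both others lie beyond the scatter. Compound 4 `Cc1ccc(N(C2CCC2)S(=O)(=O)c2ccc3c(c2)C(=O)CC(C2CCOCC2)O3)c(C)c1` has not yet been measured in this assay and differs from compound 3 in one place. The difference is cyclobutyl in place of isobutyl on a sulfonamide nitrogen and reads as cyclobutyl in place of isobutyl on a sulfonamide nitrogen.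

For the measured compounds named here, no measured step touches the isobutyl. All three exchange the substituted phenyl on a sulfonamide nitrogen, so they offer only a sense of scale: modest for a number 0.34 log units higher from compound 1 to compound 2 (beyond the scatter) and for a number 0.78 log units higher from compound 2 to compound 3 (beyond the scatter) and large for a number 1.12 log units higher from compound 1 to compound 3 (beyond the scatter) in this small set. None of them gives a direct precedent for the present change.

The estimate starts from compound 3 at 4.28 and expects a small move downward in this assay on this change of a chain for a ring. The expected step is a number 0.28 log units lower from compound 3 to compound 4 (within the scatter) and sits close to the scatter. Compound 4 is expected at 4 as a middle value. The estimated range for compound 4 runs from 3.5 to 4.45 for now.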

Compound 4, distribution coefficient: 3.86
Compound 4: middle estimate off by 0.14 log units, on the high side; low and high end bracket the measured number.
By their numbers in this assay, from the lowest: compound 1; then compound 2; then compound 4; then compound 3.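

In this assay, for the compounds shown here, the alkyl place on the sulfonamide nitrogen now has its first measured change, and the step is a number 0.42 log units lower from compound 3 to compound 4 (beyond the scatter) with the 2,4-dimethylphenyl held fixed, so this place moves the read-out as well as the aryl place varied in the earlier steps. Isobutyl and cyclobutyl have the same count of four carbon heavy atoms and differ in that cyclobutyl holds one four-membered non-aromatic ring of carbon only, so a change from chain to ring with no change in that count still gives a step beyond the scatter, though on the strength of this single pair. No measurement at hand offers an explanation for the direction or the size of this step.

Cyclobutyl appears here only with 2,4-dimethylphenyl, and whether the step from isobutyl carries over to the 3-fluorophenyl or 4-cyanophenyl compounds remains open. Also open, from the compounds shown here alone, is how a cyclopentyl ring, a longer chain or an amine at this place on the sulfonamide nitrogen would compare with isobutyl and cyclobutyl in this assay on the same core.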